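A few compounds are considered here, and "the series" means these few. Any claim that something is new, unique, unknown or untested is made for them only; others in the source may bear on it.

Working notes on the series built on the shared core of compound 1 `O=C(CCc1cccc2c1B(O)OC2)Nc1ccccc1`, read in a functional assay on SK-OV-3 cells (Homo sapiens) for antiproliferative activity, read by MTT assay, with a stated time of 72 h; on this read-out lower numbers stand for stronger inhibition and higher numbers for weaker inhibition. Compound 1 gives 200 nM, compound 2 `O=C(CCc1cccc2c1B(O)OC2)Nc1ccc(F)cc1` gives 720 nM, and compound 3 `O=C(CCc1cccc2c1B(O)OC2)Nc1ccc([N+](=O)[O-])cc1` gives 83000 nM, so compound 2 holds the middle place among the three numbers.

Next in line is compound 4 `O=C(CCc1cccc2c1B(O)OC2)Nc1cccc(I)c1`, with the change 3-iodophenyl in place of 4-fluorophenyl on an amide-type nitrogen. Going by the values given here, no measured compound carries a 3-iodophenyl group, so the evidence is indirect. Among the compounds with values here, two measured steps bear on it. The fluoro step, a 3.6-fold higher number from compound 1 to compound 2 (0.56 log units; beyond the scatter), is modest. The nitro step, a 420-fold higher number from compound 1 to compound 3 (2.62 log units; beyond the scatter), is large, and a 120-fold higher number from compound 2 to compound 3 (2.06 log units; beyond the scatter) is also large. Within the data shown here, both added groups raised the number, but compound 2, the only halogen example, is the closer guide, with its modest step. No step beyond the scatter is therefore expected in this assay, though the uncertainty is wide. The expected step is a 1.3-fold higher number from compound 2 to compound 4 (0.10 log units; within the scatter). Compound 4 is expected at 900 nM, with an estimated range of 150 nM to 6000 nM.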

Compound 4, half-maximal inhibitory concentration: 630 nM
Compound 4: middle estimate off by 1.4-fold (0.15 log units), on the high side; low and high end bracket the measured number.
By their numbers in this assay, from the lowest: compound 1; then compounds 4 and 2 (each within the scatter of the next); then compound 3.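

In this assay the step of a 1.1-fold lower number from compound 2 to compound 4 (0.06 log units; within the scatter) shows that 3-iodophenyl and 4-fluorophenyl on the amide-type nitrogen cannot be told apart, although the halogen and its ring position both change. The step of a 3.2-fold higher number from compound 1 to compound 4 (0.50 log units; beyond the scatter) gives a second halogen example with a modest rise relative to the unsubstituted phenyl of compound 1. Among the substituted compounds, the large step of a 420-fold higher number from compound 1 to compound 3 (2.62 log units; beyond the scatter) therefore remains confined to the nitro group of compound 3.

From the compounds shown here alone, because halogen and position change together here, their separate contributions stay unresolved, and it remains open how an amine or a carboxylic acid in place of the halogen would read. The data shown offer no measurement that explains why the two halogen compounds read alike.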